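The source may hold more compounds than are shown below. What is called first, only, known or untested is meant among the compounds shown, and "the series" means these compounds.

Measured so far in a functional assay on SW620/5-FU cells (Homo sapiens) for cytotoxicity, read by MTT assay, with a stated time of 48 h, in the presence of a further agent that is not named here; a higher number here means that more compound is needed for the effect, a lower number that less compound is needed:
compound 1, `COc1ccc(-c2cc(NNC(=O)Nc3cc(Cl)nc(Cl)c3)nc3c2cnn3C)cc1`: 18500 nM
compound 2, `Cn1ncc2c(-c3ccc(F)cc3)cc(NNC(=O)Nc3cc(Cl)nc(Cl)c3)nc21`: 9150 nM
compound 3, `CCCCOc1cc(NC(=O)NNc2cc(-c3ccc(OC)cc3)c3cnn(C)c3n2)cc(Cl)n1`: 39200 nM

The three measured compounds differ at two places. Compound 1 and compound 2 differ only on the phenyl ring; the change is fluoro in place of methoxy on an aromatic carbon and in this assay it gave a 2.0-fold lower number from compound 1 to compound 2 (0.31 log units; beyond the scatter). Compound 3 carries a different core; its difference from compound 1 is butoxy in place of chloro on an aromatic carbon, and that change gave a 2.1-fold higher number from compound 1 to compound 3 (0.33 log units; beyond the scatter), leaving compound 3 with the highest number of the three. Among the compounds with values here, no step is counted between compound 2 and compound 3; their two values show compound 2 with the lower number.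

Compound 4, `CCCCOc1cc(NC(=O)NNc2cc(-c3ccc(F)cc3)c3cnn(C)c3n2)cc(Cl)n1`, is not yet measured. It stands to compound 3 as compound 2 stands to compound 1: the change is fluoro in place of methoxy on an aromatic carbon, and the place of the change reads the same, word for word, as for compound 1 to compound 2, so it is the same change, made on the core of compound 3 rather than the core of compound 1. Whether the change carries over rests on a single pair, compound 1 and compound 2, whose step a 2.0-fold lower number from compound 1 to compound 2 (0.31 log units; beyond the scatter) was modest but beyond the scatter. On that basis the corresponding step in this assay is expected to be about as large, a 2.0-fold lower number from compound 3 to compound 4 (0.30 log units; within the scatter). Compound 4 is therefore estimated at 19600 nM in this assay, with an expected range from 9000 nM to 45000 nM.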

Compound 4, half-maximal effective concentration: 29300 nM
For compound 4 the middle estimate is 1.5-fold (0.17 log units) below the measured one; the range from low to high includes it.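

In this assay, going from 4-methoxyphenyl to 4-fluorophenyl on the core of compound 3 gave a 1.3-fold lower number from compound 3 to compound 4 (0.13 log units; within the scatter), a step that on its own cannot be told from no change, yet it does not differ from the earlier step for this change: the same change on two cores in this assay, a 2.0-fold lower number (0.31 log units; beyond the scatter) from compound 1 to compound 2 and a 1.3-fold lower number (0.13 log units; within the scatter) from compound 3 to compound 4, 1.5-fold (0.18 log units) apart, within the scatter of two such steps. Butoxy in place of chloro, made on the compounds that carry 4-fluorophenyl, gave a 3.2-fold higher number from compound 2 to compound 4 (0.51 log units; beyond the scatter), and this step also agrees with its earlier counterpart: the same change on two cores in this assay, a 2.1-fold higher number (0.33 log units; beyond the scatter) from compound 1 to compound 3 and a 3.2-fold higher number (0.51 log units; beyond the scatter) from compound 2 to compound 4, 1.5-fold (0.18 log units) apart, within the scatter of two such steps. Across these four compounds, then, each change is consistent with carrying over from one core to the other, but each comparison rests on only two pairs of compounds, and this does not show that the fluoro step is real on the core of compound 3, that either change would hold on any further core, or why the steps take the size they do.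

The compounds shown leave open how an amine or a trifluoromethyl group would behave in place of the fluoro group on the phenyl ring. They also leave open whether a shorter or a longer chain in place of butoxy would follow the same step.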